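Sulfonyl aryl fluorine pattern and clearance in the shared core

The compounds below may be only part of what the source reports. "The series", "measured", "known", "first", "only" and "open" are said of these compounds alone.

Measured so far:
- Compound 1, `O=S(=O)(c1cccc(F)c1)c1cnc2c(F)cccc2c1-c1cccc(Cl)c1`, 0.56 mL/min
- Compound 2, `O=S(=O)(c1ccc(F)cc1)c1cnc2c(F)cccc2c1-c1cccc(Cl)c1`, 1.21 mL/min

Both were run in an ADME assay on microsomes from liver (Homo sapiens) for metabolic stability, tested at 2.5 uM; a higher number here means faster removal of the compound, a lower number slower removal. Compound 2 gives the higher of the two numbers, with compound 1 the nearer and only neighbour; the step of a 2.2-fold higher number from compound 1 to compound 2 (0.33 log units; beyond the scatter) is modest but beyond the scatter.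

The next compound, compound 3, `O=S(=O)(c1ccc(F)c(F)c1)c1cnc2c(F)cccc2c1-c1cccc(Cl)c1`, keeps the sulfonyl aryl group of compound 2 and adds one change: fluoro in place of hydrogen on an aromatic carbon. Read one bond further out, the sulfonyl aryl group goes from 4-fluorophenyl to 3,4-difluorophenyl, the new fluoro sitting ortho to the fluoro already present and meta to the large group.

Among the compounds with values here, no measured step tells what a second fluoro on this aryl group does; the only step recorded, from compound 1 to compound 2, moves a single fluoro from one position to another and is of modest size. Compound 3 retains the 4-fluoro of compound 2, so its number is expected to stay near that of compound 2, with the step of a 1.2-fold lower number from compound 2 to compound 3 (0.08 log units; within the scatter) expected to lie within the scatter in either direction. Compound 3 is therefore estimated at 1 mL/min, in the range 0.5 mL/min to 2 mL/min.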

Compound 3, intrinsic clearance in a liver preparation (reported as CLH), per the amount of preparation that the assay uses: 1.13 mL/min
The estimate for compound 3 lay 1.1-fold (0.05 log units) below the measured number; the range from low to high includes it.
By their numbers in this assay, from the lowest: compounds 1, 3 and 2 (each within the scatter of the next, the first and the last beyond it).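

In this assay, fluoro in place of hydrogen on an aromatic carbon, ortho to the fluoro group already present, gives a step that cannot be told from repeat measurement (a 1.1-fold lower number from compound 2 to compound 3 (0.03 log units; within the scatter)), so 4-fluorophenyl and 3,4-difluorophenyl on the sulfonyl sulfur are not separated by these data. Read from compound 1, where the same kind of change also adds a fluoro to the aryl group, the step (a 2.0-fold higher number from compound 1 to compound 3 (0.30 log units; within the scatter)) likewise stays within the scatter, while the step between the two single-fluoro compounds (a 2.2-fold higher number from compound 1 to compound 2 (0.33 log units; beyond the scatter)) lies beyond it, which places compound 3 unresolved from both of them. No supporting measurement is available to explain why the numbers fall this way.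

Still open, from the compounds shown here alone, is whether this insensitivity to a second fluoro extends to other groups on the sulfonyl aryl ring, such as a methoxy, a nitrile or an amine. Also open, going by these compounds, is how an unsubstituted phenyl on the sulfonyl sulfur would compare with the fluorinated aryl groups in the shared core.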